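Hydrazone series: removing the chloro from compound 2

A few compounds are considered here, and "the series" means these few. Any claim that something is new, unique, unknown or untested is made for them only; others in the source may bear on it.

Of the compounds shown here, two have numbers so far. Compound 1 `COc1ccc(OC)c(/C=C/c2nnc(Nc3ccc(Cl)cc3)o2)c1` gives 9660 nM in a functional assay on SK-MEL-2 cells (Homo sapiens) for antiproliferative activity, read by sulforhodamine B assay, with a stated time of 48 h; a higher number here means a weaker inhibitor of growth, a lower number a stronger inhibitor of growth. Compound 2 `COc1ccc(OC)c(/C=C/C(=O)N/N=C/c2ccc(Cl)cc2)c1` gives 24700 nM in this assay, the higher of the two numbers; the gap between compound 2 and compound 1 lies beyond the scatter, so compound 2 stands as the weaker inhibitor of growth of the pair. Among the measured compounds shown here, no step between compounds differing in one place is available, so nothing about the effect of a single change has yet been measured directly.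

Compound 3 `COc1ccc(OC)c(/C=C/C(=O)N/N=C/c2ccccc2)c1` is the next member to be tested in this assay. It differs from compound 2 by hydrogen in place of chloro on an aromatic carbon. With no measured step of this kind in the series, the expected step from compound 2 to compound 3, a 1.2-fold higher number from compound 2 to compound 3 (0.08 log units; within the scatter), is set close to none beyond the scatter, leaning slightly toward a higher number. Compound 3 is therefore estimated at 30000 nM in this assay, with a range from 10000 nM to 90000 nM.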

Compound 3, concentration for 50% growth inhibition: 2980 nM
Compound 3: the middle estimate sits 10-fold (1.00 log units) above what was measured, outside the stated range (below it).
By their numbers in this assay, from the lowest: compound 3; then compound 1; then compound 2.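

First single-change step in the series: in this assay, going from 4-chlorophenyl to phenyl gives an 8.3-fold lower number from compound 2 to compound 3 (0.92 log units; beyond the scatter) and so shows directly that this place on the aromatic ring, para to a large group, is sensitive to what it carries, which the earlier pair, differing in more than one place, could not show. For this pair, growth inhibition does not depend on the chloro, and the number is lower with hydrogen at this place, so a single chlorine atom is enough to move the read-out well beyond the usual scatter. No measurement at hand bears on why the exchange of chloro for hydrogen has this size.

Open, on these data alone, is how other groups at the same place would stand against hydrogen and chloro, for instance fluoro, methyl, an amine or a carboxylic acid, and so whether the step reflects the loss of chloro in particular or a wider preference for an unsubstituted ring. Also open, as far as these compounds go, is whether the same exchange of 4-chlorophenyl for phenyl on the core of compound 1 would give a step of similar direction and size.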